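A few compounds are considered here, and "the series" means these few. Any claim that something is new, unique, unknown or untested is made for them only; others in the source may bear on it.

Three closely related compounds have been tested in a functional assay on MDA-MB-231 cells (Homo sapiens) for cytotoxicity, read by MTT assay, with a stated time of 72 h; a lower number here means a stronger inhibitor, a higher number a weaker inhibitor. Compound 1 `COc1cc2c(Oc3ccc(NC(=O)c4nn(-c5ccc(F)cc5)c(=O)c5ccccc45)cc3F)ccnc2cc1OCCCN1CCN(C)CC1` gives 460 nM. Compound 2 `COc1cc2c(Oc3ccc(NC(=O)c4nn(-c5ccccc5)c(=O)c5ccccc45)cc3F)ccnc2cc1OCCCN1CCCCC1` gives 1880 nM, and compound 3 `COc1cc2c(Oc3ccc(NC(=O)c4nn(-c5ccccc5)c(=O)c5ccccc45)cc3F)ccnc2cc1OCCCN1CCC(C)CC1` gives 1480 nM. Going by the values given here, the only pair that differs in a single place is a 1.3-fold lower number from compound 2 to compound 3 (0.10 log units; within the scatter), a change on the saturated ring at the end of the chain that leaves the result essentially unchanged. Compound 3 thus stands second highest of the three numbers, with compound 2 nearest and compound 1 furthest, the latter a lower number beyond the scatter. Compound 1 differs from compound 3 in two places at once, so its lower number cannot be assigned to either of them.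

Compound 4 `COc1cc2c(Oc3ccc(NC(=O)c4nn(-c5ccc(F)cc5)c(=O)c5ccccc45)cc3F)ccnc2cc1OCCCN1CCC(C)CC1` has not yet been tested. It differs from compound 3 in one place: fluoro in place of hydrogen on an aromatic carbon. Among the compounds with values here, no measured step isolates this change, so the expectation rests only on the observation that compound 1 also carries the 4-fluorophenyl and gives the lowest of the three numbers. In this assay compound 4 is therefore expected to show a 1.5-fold lower number from compound 3 to compound 4 (0.17 log units; within the scatter), a modest move toward a lower number that may well stay within the scatter. The estimate for compound 4 is 1000 nM, with a likely range from 400 nM to 2800 nM.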

Compound 4, half-maximal inhibitory concentration: 660 nM
Beside the measured number, compound 4's estimate is 1.5-fold (0.18 log units) above it; the range from low to high includes it.
By their numbers in this assay, from the lowest: compounds 1 and 4 (each within the scatter of the next); then compounds 3 and 2 (each within the scatter of the next).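

Phenyl to 4-fluorophenyl can now be read on its own: in this assay the change gives a 2.2-fold lower number from compound 3 to compound 4 (0.35 log units; beyond the scatter) and so, though modest, stands clear of the usual variation between repeats at this aromatic carbon, para to a large group. The new compound also connects compound 1 to the others, since with the 4-fluorophenyl held fixed, exchanging 4-methylpiperazin-1-yl for 4-methylpiperidin-1-yl gives a 1.4-fold higher number from compound 1 to compound 4 (0.16 log units; within the scatter) and shows no clear difference at the end of the chain. Nothing measured here offers a reason for the effect of the fluoro group.

Going by these compounds, the fluoro step rests on a single pair of compounds, so whether it would carry over to other groups at the end of the chain remains open. It is also unknown how chloro, methoxy or an amine such as dimethylamino at the same aromatic carbon would compare with fluoro.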